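Positional methyl move on the benzoyl hydrazide series

The compounds below may be only part of what the source reports. "The series", "measured", "known", "first", "only" and "open" are said of these compounds alone.

Measured so far in an assay on cells for agonist activity at ecdysone receptor (Bombyx mori), read by a luciferase reporter, with a stated time of 24 h; on this read-out lower numbers stand for an effect already at smaller amounts and higher numbers for an effect only at larger amounts of compound:
compound 1 `CC(C)(C)N(NC(=O)c1ccccc1)C(=O)c1ccccc1Cl` gives 75.9 nM
compound 2 `CC(C)(C)N(NC(=O)c1ccccc1)C(=O)c1ccccc1C(F)(F)F` gives 631 nM
compound 3 `Cc1ccccc1C(=O)NN(C(=O)c1ccccc1Cl)C(C)(C)C` gives 72.4 nM

Compound 3 has the lowest of the three numbers in this assay, but its nearest neighbour is compound 1, with a gap within the scatter, so the two cannot be ordered; compound 2 lies well apart from both.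

The next compound is compound 4 `Cc1cccc(C(=O)NN(C(=O)c2ccccc2Cl)C(C)(C)C)c1`. Relative to compound 3 the change is 3-methylphenyl in place of 2-methylphenyl on a carbonyl carbon; the two have the same atoms, joined differently.

Neither measured step tests the same change directly. The step of a 1.0-fold lower number from compound 1 to compound 3 (0.02 log units; within the scatter) shows that adding a methyl to this ring leaves the number essentially unchanged. The step of an 8.3-fold higher number from compound 1 to compound 2 (0.92 log units; beyond the scatter) concerns the other ring and a different group, so it bears only loosely here. With a methyl already tolerated on this ring and no evidence that its placement matters, no step beyond the scatter is expected from compound 3 to compound 4, and a 1.2-fold higher number from compound 3 to compound 4 (0.09 log units; within the scatter) is the estimated step.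

For compound 4 the expected value in this assay is 90 nM, with a likely range of 30 nM to 300 nM.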

Compound 4, half-maximal effective concentration: 603 nM
Estimate against measurement, compound 4: 6.7-fold (0.83 log units) below; measured number outside the range, above it.
By their numbers in this assay, from the lowest: compounds 3 and 1 (each within the scatter of the next); then compounds 4 and 2 (each within the scatter of the next).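

In this assay, where the methyl sits on this ring matters: 3-methylphenyl in place of 2-methylphenyl on a carbonyl carbon gives an 8.3-fold higher number from compound 3 to compound 4 (0.92 log units; beyond the scatter), although the two compounds have the same atoms. Methyl in place of hydrogen on an aromatic carbon therefore cannot be read as one uniform change, since with 2-methylphenyl it gives a 1.0-fold lower number from compound 1 to compound 3 (0.02 log units; within the scatter), while with 3-methylphenyl it gives a 7.9-fold higher number from compound 1 to compound 4 (0.90 log units; beyond the scatter). No measurement at hand gives a reason for this gap between the two methylphenyl groups.

Methyl is the only group varied on this ring here, so it remains open whether an ethyl, a methoxy or an amine would follow the number of the 2-methylphenyl or of the 3-methylphenyl. Going by these compounds, it is also open whether the gap between the two methylphenyl groups would persist with trifluoromethyl in place of chloro, as in compound 2, since compound 3 and compound 4 both carry the chloro.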